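Arylpiperazine series: methyl to chloro on the aryl ring

A few compounds are considered here, and "the series" means these few. Any claim that something is new, unique, unknown or untested is made for them only; others in the source may bear on it.

Compound 2 `CCC1(CCCCN2CCN(c3ccc(C)c(Cl)c3)CC2)C(=O)Nc2ccccc21` gives the lowest number of the three measured in an assay on CHO cells for displacement of a labelled ligand from 5-hydroxytryptamine receptor 7 (Homo sapiens) (a higher number here means a weaker inhibitor, a lower number a stronger inhibitor), at 0.66 nM. Compound 3 `CCC1(CCCCN2CCN(c3ccc(F)cc3)CC2)C(=O)Nc2ccc(F)cc21` gives 1.5 nM in this assay, and compound 1 `CCC1(CCCCN2CCN(c3cccc(OC)c3)CC2)C(=O)Nc2ccccc21` gives 2.55 nM. For the measured compounds named here, the one single-point step among them is a 3.9-fold lower number from compound 1 to compound 2 (0.59 log units; beyond the scatter). Compound 4 `CCC1(CCCCN2CCN(c3ccc(Cl)c(Cl)c3)CC2)C(=O)Nc2ccccc21` differs from compound 2 by chloro in place of methyl on an aromatic carbon. Going by the values given here, no measured step exchanges methyl for chloro, so the gain seen from compound 1 to compound 2 bears only loosely on this change. In this assay compound 4 is therefore expected to stay close to compound 2, with a step of a 1.1-fold higher number from compound 2 to compound 4 (0.03 log units; within the scatter) that is expected to lie within the scatter. The estimate for compound 4 is 0.7 nM, with a range from 0.3 nM to 1.6 nM.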

Compound 4, inhibition constant: 0.63 nM
Beside the measured number, compound 4's estimate is 1.1-fold (0.05 log units) above it, and the stated range covers the measured number.
By their numbers in this assay, from the lowest: compounds 4 and 2 (each within the scatter of the next); then compounds 3 and 1 (each within the scatter of the next).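

Chloro in place of methyl, ortho to a chloro group and para to a large group, leaves the number in this assay within the scatter (a 1.0-fold lower number from compound 2 to compound 4 (0.02 log units; within the scatter)). The 3,4-dichlorophenyl group keeps the gain over the 3-methoxyphenyl group (a 4.0-fold lower number from compound 1 to compound 4 (0.61 log units; beyond the scatter)), so that gain does not need the methyl of compound 2. No evidence on hand explains why methyl and chloro read alike here. The compounds shown leave open how a trifluoromethyl group, an amine or a carboxylic acid would read at this position. Also open, on these data alone, is whether the 3-chlorophenyl group, with only hydrogen there, would hold the same level.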